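The source may report more compounds than this note shows. Statements on the series, on what has been measured and on what is new or still open speak of the compounds shown alone.

Compound 3 `CCOC(=O)CCCCCOc1cccc(CN(C(=O)c2ccc(-c3ccc4ccccc4c3)cc2)C(C)C)c1` is one of three compounds tested in an ADME assay on Raji cells (Homo sapiens) for cytotoxicity, read by CellTiter-Glo and resazurin assay, with a stated time of 72 h; a lower number here means that less compound is needed, a higher number that more compound is needed for the effect. In this assay compound 3 gives > 26000 nM, which is a limit of the assay and not a number. Compound 2 `CCOC(=O)CCCCCOc1cccc(CN(C(=O)c2ccc(-c3cccc4ccccc34)cc2)C(C)C)c1` gives > 26000 nM, also a limit. Compound 1 `CC(C)N(Cc1cccc(OCCCCCC(=O)O)c1)C(=O)c1ccc(-c2cccc(-c3ccccc3)c2)cc1` gives > 26000 nM, likewise a limit. The step that the two limits leave unreadable from compound 2 to compound 3 therefore cannot be read, and all three values sit together (the limit of > 26000 nM in this assay, at which 3 of the 3 values shown sit). Compound 4 `CCOC(=O)CCCCCOc1cccc(CN(C(=O)c2ccc(-c3cccc(-c4ccccc4)c3)cc2)C(C)C)c1` is not yet measured; it differs from compound 3 in that (3-phenylphenyl in place of naphthalen-2-yl on an aromatic carbon). Compound 1 already carries the same 3-phenylphenyl group and differs from compound 4 only in its chain, a carboxylic acid where compound 4 has an ethyl ester, and its value is a limit as well. With every measured step hidden by the limit (the limit of > 26000 nM in this assay, at which 3 of the 3 values shown sit), no step beyond the scatter is expected in this assay. The estimate for compound 4 is 40000 nM, between 20000 nM and 100000 nM, and the expected step that the limit leaves unreadable from compound 3 to compound 4 amounts to nothing readable.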

Compound 4, half-maximal effective concentration: > 26000 nM
Compound 4: a limit, no number (the forecaster's own chance of this, stated with the estimate: 85%); the middle value lies beyond the limit too.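

Among the compounds shown here, no step from compound 1, compound 2 or compound 3 to compound 4 can be read, because all four compounds stop at the same limit: the limit of > 26000 nM in this assay, at which 4 of the 4 values shown sit.
The compounds shown leave open in this assay at what concentration, if any, each compound reaches its half-maximal effect, and so how much any of these changes matters.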